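Three Terpenoid Compounds at the Limit, and an Isomer to Come

The source may report more compounds than this note shows. Statements on the series, on what has been measured and on what is new or still open speak of the compounds shown alone.

The three measured compounds are compound 1 `CC(=O)O[C@H](C/C=C(\C)CC/C=C(\C)CCC1=C(C)CCC(=O)C1(C)C)C1=CC(=O)OC1`, compound 2 `CC1=C(CCC(C)(O)/C=C/C/C(C)=C/CCC2=CC(=O)OC2O)C(C)(C)CCC1` and compound 3 `CC1=C(CC/C(C)=C/CC/C(C)=C/C[C@@H](O)C2=CC(=O)OC2)C(C)(C)CCC1`. All three were tested in a functional assay on MDA-MB-231 cells (Homo sapiens) for antiproliferative activity, read by sulforhodamine B assay, with a stated time of 48 h; on this read-out lower numbers stand for stronger inhibition and higher numbers for weaker inhibition. In this assay compound 1 gives > 10000 nM, which is a limit of the assay and not a number. Compound 2 likewise gives only a limit, > 10000 nM. Compound 3 also gives only a limit, > 10000 nM. Among the measured compounds shown here, compound 3 therefore cannot be placed above or below the other two on these numbers: each of the three values sits at the same limit, as summed up in the limit of > 10000 nM in this assay, at which 3 of the 3 values shown sit, and no step between measured compounds can be computed.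

The unmeasured compound is compound 4 `CC1=C(CC/C(C)=C/CC/C(C)=C/CCC2=CC(=O)OC2O)C(C)(C)CCC1`. It has the same atoms as compound 3, joined differently: a group of 8 heavy atoms (5 carbon, 3 oxygen; one five-membered non-aromatic ring with 1 hetero atom) in place of a group of 8 heavy atoms (5 carbon, 3 oxygen; one five-membered non-aromatic ring with 1 hetero atom), on a saturated chain carbon bound to a double-bonded chain carbon.

For the measured compounds named here, since no measured step exists, the size of the step from compound 3 to compound 4 in this assay can only be guessed from the fact that every value shown is a limit. The expected step that the limit leaves unreadable from compound 3 to compound 4 is none beyond the scatter, with compound 4 most likely staying at the limit as well. The estimate for compound 4 in this assay is 15000 nM, with a range from 5000 nM to 50000 nM.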

Compound 4, half-maximal inhibitory concentration: 4500 nM
Estimate against measurement, compound 4: 3.3-fold (0.52 log units) above; measured number outside the range, below it.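

In this assay compound 3 gives > 10000 nM, which is a limit of the assay and not a number. Exchanging one group of the same atoms for another, on a saturated chain carbon bound to a double-bonded chain carbon, gives an at least 2.2-fold lower number from compound 3 to compound 4 (0.34 log units; beyond the scatter), so this place in the molecule can change the read-out even when the atom content stays the same, and the printed step is only the smallest size it can have. Compound 4 is the first compound here to give a number in place of a limit, while the others stay where they were: the limit of > 10000 nM in this assay, at which 3 of the 4 values shown sit.

The two groups differ in how their atoms are joined, and the leaving group has a defined stereocentre that the entering group does not, so the compounds shown do not tell which of these features goes with the step. They also leave open what an amine, a carboxylic acid or a longer chain at this same place would do to the antiproliferative read-out, and whether any such group would move the number further in either direction.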